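Bromo for Fluoro on the Aryl Group at Nitrogen

The source may hold more compounds than are shown below. What is called first, only, known or untested is meant among the compounds shown, and "the series" means these compounds.

Compound 3 `O=C(Nc1cccc(OCc2cn(-c3ccccc3F)nn2)c1)Nc1ccc(Cl)c(C(F)(F)F)c1` gives 1520 nM in a functional assay on HepG2 cells (Homo sapiens) for inhibition, read by MTT assay, with a stated time of 72 h (on this read-out lower numbers stand for stronger inhibition and higher numbers for weaker inhibition), the second highest of three numbers. Its nearest neighbour is compound 1 `COc1cccc(-n2cc(COc3cccc(NC(=O)Nc4ccc(Cl)c(C(F)(F)F)c4)c3)nn2)c1`, with 1310 nM; compound 2 `CC(C)c1ccc(-n2cc(COc3cccc(NC(=O)Nc4ccc(Cl)c(C(F)(F)F)c4)c3)nn2)cc1` gives 2470 nM. The steps of a 1.9-fold higher number from compound 1 to compound 2 (0.28 log units; within the scatter), a 1.2-fold higher number from compound 1 to compound 3 (0.06 log units; within the scatter) and a 1.6-fold lower number from compound 2 to compound 3 (0.21 log units; within the scatter) all exchange the aryl group on the aromatic nitrogen, and each stays within the scatter. Compound 4 `O=C(Nc1cccc(OCc2cn(-c3ccccc3Br)nn2)c1)Nc1ccc(Cl)c(C(F)(F)F)c1` carries bromo in place of fluoro on an aromatic carbon. Within the data shown here, no measured step exchanges one halogen for another, so the only guidance is that varied aryl groups on this nitrogen have so far moved the numbers little. Compound 4 is therefore expected to show a 1.0-fold lower number from compound 3 to compound 4 (0.01 log units; within the scatter), nothing beyond the scatter, with an estimate of 1500 nM in this assay, ranging from 700 nM to 3200 nM.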

Compound 4, half-maximal inhibitory concentration: 2810 nM
For compound 4 the middle estimate is 1.9-fold (0.27 log units) below the measured one, within the range that was stated.
By their numbers in this assay, from the lowest: compounds 1, 3, 2 and 4 (each within the scatter of the next, the first and the last beyond it).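

The exchange of fluoro for bromo at this place, ortho to a large group, gives a 1.8-fold higher number from compound 3 to compound 4 (0.27 log units; within the scatter) in this assay, so these two halogens cannot be told apart here. The 2-bromophenyl group also stays within the scatter of the 4-isopropylphenyl group, a 1.1-fold higher number from compound 2 to compound 4 (0.06 log units; within the scatter), yet it gives the only step among these aryl groups that passes the scatter, a modest one, a 2.1-fold higher number from compound 1 to compound 4 (0.33 log units; beyond the scatter). Nothing shown gives a reason for these steps. As far as these compounds go, whether 2-chlorophenyl, or an amine or a carboxylic acid on this aryl ring, would move the number further remains open.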